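The compounds below may be only part of what the source reports. "The series", "measured", "known", "first", "only" and "open" are said of these compounds alone.

Of the compounds shown here, three built on one shared core have been measured in an assay on isolated protein for inhibition of Voltage-dependent L-type calcium channel subunit alpha-1C (Cavia porcellus); on this read-out lower numbers stand for stronger inhibition and higher numbers for weaker inhibition. Compound 1 `COC(=O)C1=C(C)NC(C)=C(C(=O)OC)C1c1[nH]cnc1Cl` gives 1200 nM. Compound 2 `CCCOC(=O)C1=C(C)NC(C)=C(C(=O)OC)C1c1[nH]cnc1Cl` gives 437 nM, and compound 3 `COC(=O)C1=C(C)NC(C)=C(C(=O)OC(C)(C)C)C1c1[nH]cnc1Cl` gives 1860 nM. Compound 3 therefore carries the highest of the three numbers: the step of a 1.6-fold higher number from compound 1 to compound 3 (0.19 log units; within the scatter) leaves it within the scatter of compound 1, whereas the step of a 4.3-fold higher number from compound 2 to compound 3 (0.63 log units; beyond the scatter) sets it clearly apart from compound 2.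

The next compound, compound 4 `COC(=O)C1=C(C)NC(C)=C(C(=O)OCc2ccccc2)C1c1[nH]cnc1Cl`, differs from compound 3 in a single place: benzyl in place of tert-butyl on an oxygen next to a carbonyl group. Two of the measured steps concern the same oxygen next to a carbonyl group and bear on this change. The step of a 2.7-fold lower number from compound 1 to compound 2 (0.44 log units; beyond the scatter) showed that a larger group on that oxygen lowered the number, while the step of a 4.3-fold higher number from compound 2 to compound 3 (0.63 log units; beyond the scatter) showed that the tert-butyl group raised it again. Benzyl is larger than tert-butyl and, like propyl, is not branched, so a modest move back toward the number of compound 2 is expected, amounting to the step of a 3.1-fold lower number from compound 3 to compound 4 (0.49 log units; beyond the scatter). Compound 4 is accordingly expected to give 600 nM, with a range from 250 nM to 1500 nM.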

Compound 4, half-maximal inhibitory concentration: 93.3 nM
Beside the measured number, compound 4's estimate is 6.4-fold (0.81 log units) above it; the measured number lies below the stated range.
By their numbers in this assay, from the lowest: compound 4; then compound 2; then compounds 1 and 3 (each within the scatter of the next).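

In this assay, among these compounds, the group on an oxygen next to a carbonyl group proves able to move the number much further than the earlier compounds suggested: methyl, propyl and tert-butyl spanned only a modest range, whereas the change to benzyl gives a 20-fold lower number from compound 3 to compound 4 (1.30 log units; beyond the scatter) and, against the methyl group, a 13-fold lower number from compound 1 to compound 4 (1.11 log units; beyond the scatter). Length of an unbranched chain does not account for the whole of this result on its own, as phenyl in place of ethyl on the saturated chain carbon bound to that oxygen still gives a 4.7-fold lower number from compound 2 to compound 4 (0.67 log units; beyond the scatter), so the phenyl ring does more at this place than the propyl chain of compound 2. Nothing measured here explains why the benzyl group has this effect.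

The compounds shown leave open whether the phenyl ring must sit directly on that chain carbon, which a phenethyl or pyridylmethyl group could test, and whether a chlorine or methoxy group on the ring would lower the number further. They also leave open how benzyl would behave with anything other than the methyl group on the second such oxygen, such as an ethyl group.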